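A Larger Group on the Five-Membered Ring

The source may hold more compounds than are shown below. What is called first, only, known or untested is meant among the compounds shown, and "the series" means these compounds.

Compound 1 `Cc1ccc(-c2c(S(=O)(=O)c3ccccc3)cnc3cc(C)nn23)cc1` has the highest of the three numbers measured in a functional assay on the whole organism for inhibition, with Mus musculus as the target, with a stated time of 6 h, at a dose of 50 mg/kg by the oral route (a higher number here means more inhibition at the dose given (going by the name of the read-out), a lower number less inhibition), where compound 1 gives 8.7%, though both other values lie within the scatter of it. Compound 2 `Cc1ccc(-c2c(S(=O)(=O)c3ccccc3)cnc3ncnn23)cc1` gives 1.9% in this assay, and compound 3 `Cc1cc2ncc(S(=O)(=O)c3ccccc3)c(-c3ccc(Br)cc3)n2n1` gives 0%. Compound 4 `Cc1ccc(-c2cc3ncc(S(=O)(=O)c4ccccc4)c(-c4ccc(C)cc4)n3n2)cc1` differs from compound 1 by 4-methylphenyl in place of methyl on an aromatic carbon. For the measured compounds named here, no measured step touches that place of the shared core; the only step at hand, a number 8.7 percentage points lower from compound 1 to compound 3 (within the scatter), concerns a different position and is itself within the scatter, and all three measured values sit low. A step no larger than the scatter is therefore expected in this assay, a number 1.7 percentage points lower from compound 1 to compound 4 (within the scatter). Compound 4 is estimated at 7%, between 0% and 25%.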

Compound 4, a percentage reported as inhibition, in the whole organism at one dose (the size of the read-out at that dose, not a potency): 11.6%
Compound 4: middle estimate off by 4.6 percentage points, on the low side, and the stated range covers the measured number.
By their numbers in this assay, from the lowest: compounds 3, 2, 1 and 4 (each within the scatter of the next, the first and the last beyond it).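

In this assay, the step of a number 2.9 percentage points higher from compound 1 to compound 4 (within the scatter) puts 4-methylphenyl in place of methyl on the five-membered aromatic ring. This place on the shared core therefore takes a much larger group, with its six-membered aromatic ring of carbon only, without a move beyond the scatter, though the read-out stays low for both compounds. Nothing measured here accounts for this result.

From the compounds shown here alone, what an amine or a carboxylic acid at this place would give remains open. So does whether a longer chain there would lift the read-out clear of the scatter.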